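Chain extension of a chalcone-type sulfonylurea on brine shrimp

The source may hold more compounds than are shown below. What is called first, only, known or untested is meant among the compounds shown, and "the series" means these compounds.

Measured compounds:
compound 1 `Cc1ccc(S(=O)(=O)NC(=O)Nc2ccccc2C(=O)/C=C/c2ccccc2)cc1` with 25 ug/mL
compound 2 `COc1ccc(/C=C/C(=O)c2ccccc2NC(=O)NS(=O)(=O)c2ccc(C)cc2)c(OC)c1` with 16 ug/mL
compound 3 `Cc1ccc(S(=O)(=O)NC(=O)Nc2ccccc2C(=O)/C=C/c2cccc([N+](=O)[O-])c2)cc1` with 44.5 ug/mL

The read-out throughout is an ADME assay on the whole organism for cytotoxicity, with Artemia salina as the target, with a stated time of 24 h; on this read-out higher numbers stand for an effect only at larger amounts of compound and lower numbers for an effect already at smaller amounts. Compound 3 gives the highest of the three numbers: one of its two steps is a 1.8-fold higher number from compound 1 to compound 3 (0.25 log units; within the scatter), whereas the other is a 2.8-fold higher number from compound 2 to compound 3 (0.44 log units; beyond the scatter). Compound 1 and compound 2 sit close together, a 1.6-fold lower number from compound 1 to compound 2 (0.19 log units; within the scatter).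

Compound 4 `Cc1ccc(S(=O)(=O)NC(=O)Nc2ccccc2C(=O)/C=C/C=C/c2ccccc2)cc1` has not been measured in this assay. It differs from compound 3 as follows: 2-phenylethenyl in place of 3-nitrophenyl on a double-bonded chain carbon bound to a double-bonded chain carbon.

Within the data shown here, two measured steps bear on this change. The comparison of compound 1 with compound 3 shows what removal of the nitro group does at this place, a small shift within the scatter. The comparison of compound 2 with compound 3 shows that exchanging the aryl group at the same place can move the number beyond the scatter, though only modestly. Among the measured compounds shown here, no measured pair shows the effect of lengthening the chain by a second double bond. Compound 4 is therefore expected to land near compound 1, with a step of a 1.6-fold lower number from compound 3 to compound 4 (0.20 log units; within the scatter), which is expected to stay within the scatter. The estimate for compound 4 is 28 ug/mL, with a range from 12 ug/mL to 65 ug/mL.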

Compound 4, concentration for half-maximal effect: 18.2 ug/mL
Estimate against measurement, compound 4: 1.5-fold (0.19 log units) above, within the range that was stated.
By their numbers in this assay, from the lowest: compounds 2, 4, 1 and 3 (each within the scatter of the next, the first and the last beyond it).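

Among these compounds, compound 4 gives the first measured pair for lengthening the chain at this place, and in this assay 2-phenylethenyl in place of phenyl stays small (a 1.4-fold lower number from compound 1 to compound 4 (0.14 log units; within the scatter)). The same group in place of 2,4-dimethoxyphenyl also leaves the number within the scatter (a 1.1-fold higher number from compound 2 to compound 4 (0.06 log units; within the scatter)), so compound 1, compound 2 and compound 4 form one close group, while only the exchange for 3-nitrophenyl moves the number beyond the scatter, and modestly (a 2.4-fold lower number from compound 3 to compound 4 (0.39 log units; beyond the scatter)). Nothing available explains these steps.

Going by these compounds, whether a nitro group on the phenyl of 2-phenylethenyl would shift the number as it does on the shorter chain remains open. So does the outcome with a saturated chain of the same length, or with an amine or a carboxylic acid on that phenyl.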